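Replacing ethyl with tert-butyl on a ring amine

This account rests on a few compounds, and the source may have more. Where it says the series, first, only, none or still open, it means among the compounds named here.

Measured in an in vitro ADME assay on microsomes from liver (Mus musculus) for pharmacokinetics, read by LC-MS, with a stated time of 10 min, tested at 1 uM; a lower number here means slower removal, a higher number faster removal of the compound:
- Compound 1 `CN1C[C@H](C(=O)Nc2cccc(Cl)c2)[C@@H](c2ccc(/C=C/C(=O)Nc3ccccc3N)cc2)C1`: 58 mL/min/kg
- Compound 2 `CCN1C[C@H](C(=O)Nc2ccc(Cl)cc2)[C@@H](c2ccc(/C=C/C(=O)Nc3ccccc3N)cc2)C1`: 35 mL/min/kg

Compound 2, at 35 mL/min/kg, stands within the usual scatter of compound 1, at 58 mL/min/kg, so these two numbers cannot be ranked. Compound 3 `CC(C)(C)N1C[C@H](C(=O)Nc2ccc(Cl)cc2)[C@@H](c2ccc(/C=C/C(=O)Nc3ccccc3N)cc2)C1` keeps all of compound 2 except one group: tert-butyl in place of ethyl on an amine nitrogen in a ring. The change is tert-butyl in place of ethyl on an amine nitrogen in a ring. Within the data shown here, no measured pair here isolates this change, so the data offer no direct guide to its effect. The expectation therefore starts from compound 2 at 35 mL/min/kg, and no step beyond the scatter is expected in this assay. The estimated change is a 1.1-fold higher number from compound 2 to compound 3 (0.06 log units; within the scatter). For compound 3 the estimate is 40 mL/min/kg, with an expected range of 18 mL/min/kg to 85 mL/min/kg.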

Compound 3, clearance: 20 mL/min/kg
Beside the measured number, compound 3's estimate is 2.0-fold (0.30 log units) above it; the range from low to high includes it.
By their numbers in this assay, from the lowest: compounds 3, 2 and 1 (each within the scatter of the next, the first and the last beyond it).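

Among these compounds, this pair is the first to isolate a single change at this ring nitrogen: in this assay, tert-butyl in place of ethyl gives a 1.8-fold lower number from compound 2 to compound 3 (0.24 log units; within the scatter). Since that step lies within the scatter, compound 2 and compound 3 cannot be ranked, and going from the 2 heavy atoms of ethyl to the 4 of tert-butyl at this position gives no clear shift in clearance. No measurement here bears on why the two numbers fall so close together.

The compounds shown leave open whether a group of a different kind on this nitrogen, such as a cyclopropyl ring or a chain ending in a hydroxyl group, would move the number beyond the scatter. They also leave open whether the same swap would behave alike with the chlorine placed as in compound 1.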